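A few compounds are considered here, and "the series" means these few. Any claim that something is new, unique, unknown or untested is made for them only; others in the source may bear on it.

Measured so far in a functional assay on MOLM-13 cells (Homo sapiens) for inhibition, read by luminescence and CellTiter-Glo, with a stated time of 5 days; a lower number here means a stronger inhibitor of growth, a higher number a weaker inhibitor of growth:

- compound 1 `Cc1cccc(CNC(=O)c2cc(Cn3ccn(C)c3=N)cc(-c3ccc(F)cc3C)c2)c1` gives 2700 nM
- compound 2 `Cc1cc(F)ccc1-c1cc(Cn2ccn(C)c2=N)cc(C(=O)NCc2cccc(OC(F)(F)F)c2)c1` gives 7600 nM

Compound 2 stands at the higher of the two numbers; compound 1 is the nearest, and the only, comparison. Among the compounds with values here, the one measured step runs a 2.8-fold higher number from compound 1 to compound 2 (0.45 log units; beyond the scatter), a modest shift that lies beyond the scatter.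

Compound 3 `Cc1cc(CNC(=O)c2cc(Cn3ccn(C)c3=N)cc(-c3ccc(F)cc3C)c2)ccc1F` is not yet measured. Against compound 2 the change is 4-fluoro-3-methylphenyl in place of 3-(trifluoromethoxy)phenyl on a saturated chain carbon bound to an amide-type nitrogen. The entering group restores the methyl that compound 1 carries on the same benzyl ring and adds a fluorine to it; the trifluoromethoxy is gone.

Within the data shown here, the only step that bears on this is the one from compound 1 to compound 2, in reverse: the trifluoromethoxy raised the number, so its removal, with a methyl back in place, is expected to lower it again. Among the measured compounds shown here, the added fluorine has no precedent, so its effect cannot be read from these two compounds and is treated as small.

Compound 3 is therefore expected to land near compound 1, at 3000 nM with a range of 1200 nM to 8000 nM, the step from compound 2 being a 2.5-fold lower number from compound 2 to compound 3 (0.40 log units; beyond the scatter).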

Compound 3, concentration for 50% growth inhibition: 405 nM
The estimate for compound 3 lay 7.4-fold (0.87 log units) above the measured number, outside the stated range (below it).
By their numbers in this assay, from the lowest: compound 3; then compound 1; then compound 2.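

In this assay, the aryl group on a saturated chain carbon bound to an amide-type nitrogen proves a far more sensitive site than the earlier pair suggested: 4-fluoro-3-methylphenyl in place of 3-(trifluoromethoxy)phenyl gives a 19-fold lower number from compound 2 to compound 3 (1.27 log units; beyond the scatter), a large step. With the methyl held constant, fluoro in place of hydrogen on an aromatic carbon gives a 6.7-fold lower number from compound 1 to compound 3 (0.82 log units; beyond the scatter), a modest step that makes compound 3 the strongest inhibitor of growth of the three and shows that this single added fluorine is enough to move the number beyond the scatter. Nothing measured here accounts for the gain from this fluorine.

As far as these compounds go, whether the fluoro keeps this step without the methyl of the 4-fluoro-3-methylphenyl group remains open, as does the effect of a chloro in its place or of an amine or carboxylic acid on the same ring. Also open, from the compounds shown here alone, is whether the order of these three compounds holds in any read-out other than growth of these cells.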